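Replacing a phenol ring with a chloropyridine on a shared core

The compounds below may be only part of what the source reports. "The series", "measured", "known", "first", "only" and "open" are said of these compounds alone.

Measured so far:
- compound 1 `Cc1ccccc1-c1nnc(SCCn2c([N+](=O)[O-])cnc2C)o1`, 15800 nM in a functional assay on MCF7 cells (Homo sapiens) for cytotoxicity, read by MTT assay, with a stated time of 48 h; a lower number here means a stronger inhibitor, a higher number a weaker inhibitor
- compound 2 `Cc1cccc(-c2nnc(SCCn3c([N+](=O)[O-])cnc3C)o2)c1O`, 19900 nM

Both compounds were tested in this assay. Going by the values given here, compound 2, with its 2-hydroxy-3-methylphenyl group, sits next to compound 1, and the only measured step, a 1.3-fold higher number from compound 1 to compound 2 (0.10 log units; within the scatter), is within the scatter, so neither compound can be called the weaker of the two.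

Compound 3 `Cc1ncc([N+](=O)[O-])n1CCSc1nnc(-c2ccnc(Cl)c2)o1` differs from compound 2 by 2-chloropyridin-4-yl in place of 2-hydroxy-3-methylphenyl on an aromatic carbon. Among the compounds with values here, no measured step concerns a swap of this kind, since the one step known compares two carbon-only rings; it gives no direction for a change to a ring with a nitrogen and a chlorine. For compound 3 the step of a 1.1-fold lower number from compound 2 to compound 3 (0.04 log units; within the scatter) is therefore expected to stay within the scatter. Compound 3 is estimated at 18000 nM, with a range from 6000 nM to 60000 nM.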

Compound 3, half-maximal inhibitory concentration: 40500 nM
Estimate against measurement, compound 3: 2.3-fold (0.35 log units) below, and the stated range covers the measured number.
By their numbers in this assay, from the lowest: compounds 1 and 2 (each within the scatter of the next); then compound 3.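

Going by these compounds alone, at this aromatic carbon, the swap to 2-chloropyridin-4-yl gives the first change beyond the scatter in this assay: a 2.0-fold higher number from compound 2 to compound 3 (0.31 log units; beyond the scatter), and measured against the 2-methylphenyl ring, a 2.6-fold higher number from compound 1 to compound 3 (0.41 log units; beyond the scatter). Both steps are modest, but they show that this position is not indifferent to the ring it carries, since the ring with a nitrogen and a chlorine gives a weaker inhibitor than either carbon-only ring. No measurement at hand gives a reason for this shift.

The compounds shown leave open whether the ring nitrogen or the chlorine goes with the higher number, as the two enter together. They also leave open how the number would move with an amine or a carboxylic acid on this ring.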